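Ethoxy for methoxy on the arylamino side chain

The source may hold more compounds than are shown below. What is called first, only, known or untested is meant among the compounds shown, and "the series" means these compounds.

Compound 1 `Fc1ccc(Nc2nc3nonc3nc2Nc2ccccc2F)cc1` and compound 2 `COc1cccc(Nc2nc3nonc3nc2Nc2ccccc2F)c1` share one core and differ only in the aryl group on one nitrogen. In an assay on mitochondria from L6 cells (Rattus norvegicus) for activation, with a stated time of 90 min (on this read-out lower numbers stand for an effect already at smaller amounts and higher numbers for an effect only at larger amounts of compound), compound 1 gives 2300 nM. In this assay compound 2 gives 830 nM, the lower of the two numbers shown; the step of a 2.8-fold lower number from compound 1 to compound 2 (0.44 log units; beyond the scatter) exchanges the whole aryl group and is the only measured step in the set. Compound 3 `CCOc1cccc(Nc2nc3nonc3nc2Nc2ccccc2F)c1` keeps the aryl pattern of compound 2 and adds (methyl in place of hydrogen on a saturated chain carbon bound to an oxygen on an aromatic ring), so that methoxy becomes ethoxy. For the measured compounds named here, no measured step touches this chain, and the aryl exchange from compound 1 to compound 2 offers no direct guide; it shows only that this aryl group can be varied. The expectation is therefore a step not beyond the scatter, a 1.0-fold higher number from compound 2 to compound 3 (0.01 log units; within the scatter), with no preferred direction. Compound 3 is estimated at 850 nM, with a range from 300 nM to 2500 nM.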

Compound 3, half-maximal effective concentration: 2200 nM
Beside the measured number, compound 3's estimate is 2.6-fold (0.41 log units) below it; the measured number falls inside the stated range.
By their numbers in this assay, from the lowest: compound 2; then compounds 3 and 1 (each within the scatter of the next).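

In this assay this position does not tolerate the added methyl silently: methoxy to ethoxy gives a 2.7-fold higher number from compound 2 to compound 3 (0.42 log units; beyond the scatter) and so removes the advantage of the 3-methoxyphenyl group. The step of a 1.0-fold lower number from compound 1 to compound 3 (0.02 log units; within the scatter) puts 3-ethoxyphenyl level with 4-fluorophenyl, so among these three compounds only compound 2 stands apart, with its steps to both others printed as beyond the scatter. Any account of why a single methyl has this effect lacks support, as no measurement bearing on it is at hand.

Open, from the compounds shown here alone, is whether a longer chain such as propoxy would carry the rise further, or whether a hydroxy group in place of methoxy would move the number the other way. Also open, going by these compounds, is whether the methoxy-to-ethoxy step would hold with a different aryl group on the other nitrogen of the shared core.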